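Working notes: ether-to-thioether swap in a two-compound series

A few compounds are considered here, and "the series" means these few. Any claim that something is new, unique, unknown or untested is made for them only; others in the source may bear on it.

Measured compounds, in a functional assay on SNB-19 cells (Homo sapiens) for inhibition, read by sulforhodamine B assay, with a stated time of 48 h; a lower number here means a stronger inhibitor of growth, a higher number a weaker inhibitor of growth:
compound 1 `Nc1cc(N)c2nc(-c3ccccc3)c(Oc3ccc(Cl)c(Cl)c3)nc2c1` gives 52500 nM
compound 2 `COc1cc(CNc2nc3cc(N)cc(N)c3nc2-c2ccccc2)cc(OC)c1OC` gives 20900 nM

Compound 1 stands highest of the two numbers in this assay; its nearest neighbour, compound 2, gives a value lower by a margin beyond the scatter. For the measured compounds named here, no pair of measured compounds differs in a single place, so no measured step is available to carry over.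

Compound 3 `Nc1cc(N)c2nc(-c3ccccc3)c(Sc3ccc(F)cc3)nc2c1` differs from compound 1 by (4-fluorophenyl)sulfanyl in place of 3,4-dichlorophenoxy on an aromatic carbon. With nothing in the data to anchor the direction, the step from compound 1 to compound 3 in this assay is expected to be small, a 1.3-fold lower number from compound 1 to compound 3 (0.12 log units; within the scatter), and not clearly beyond the scatter. Compound 3 is estimated at 40000 nM, within 12000 nM to 130000 nM.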

Compound 3, concentration for total growth inhibition: 41700 nM
Compound 3: middle estimate off by 1.0-fold (0.02 log units), on the low side; low and high end bracket the measured number.
By their numbers in this assay, from the lowest: compounds 2, 3 and 1 (each within the scatter of the next, the first and the last beyond it).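

At this aromatic carbon next to the ring nitrogen, the swap gives a step that stays within the scatter in this assay (a 1.3-fold lower number from compound 1 to compound 3 (0.10 log units; within the scatter)). The swap exchanges the oxygen link for sulfur and the two chlorines for one fluorine at once, and the aryl ring is kept, so these changes together leave the number unmoved beyond the scatter. Nothing available accounts for this result.

The contributions of the link and the halogens remain inseparable. As far as these compounds go, whether a non-aryl group here, such as morpholine or a carboxylic acid, would shift the number also stays open.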